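Adding a methyl to the anilino ring of compound 3

This account rests on a few compounds, and the source may have more. Where it says the series, first, only, none or still open, it means among the compounds named here.

Measured compounds in a functional assay, with a stated time of 150 min, tested at 35 ug/mL; on this read-out lower numbers stand for a weaker effect and higher numbers for a stronger effect at the one concentration tested:
compound 1 `COC(=O)c1c(Nc2ccccc2)sc(C(=O)c2ccc(OC)cc2)c1C` gives 63%
compound 2 `COC(=O)c1c(Nc2ccc(C)cc2)sc(C(=O)c2ccc(OC)cc2)c1C` is reported as "not active" (no number reported)
compound 3 `COc1ccc(C(=O)c2sc(Nc3ccccc3)c(C(=O)O)c2C)cc1` gives 61.2%

Compound 3 holds the lower of the two numbers in this assay, and its difference to compound 1, a number 1.8 percentage points lower from compound 1 to compound 3 (within the scatter), lies within the scatter. Compound 4 `COc1ccc(C(=O)c2sc(Nc3ccc(C)cc3)c(C(=O)O)c2C)cc1` differs from compound 3 by methyl in place of hydrogen on an aromatic carbon, that is, anilino to (4-methylphenyl)amino. Going by the values given here, no measured step covers this change on the acid. The closest comparison is on the ester: compound 1 gives 63%, while compound 2, which carries the same methyl, is reported as "not active" (no number reported) with no number. A loss of activity is therefore expected for compound 4, estimated as 15% (range 0% to 45%), a step of a number 46.2 percentage points lower from compound 3 to compound 4 (beyond the scatter).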

Compound 4, a percentage reported as activity, at one concentration (the size of the read-out at that concentration, not a potency): "not active" (no number reported)
Nothing numeric was reported for compound 4; no gap can be computed for the estimate.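

Going by these compounds alone, compound 4 is reported without a number, so no step from compound 3 to compound 4 can be read. The compounds shown leave open how large the effect of the 4-methylphenyl group is, and no measurement here bears on a cause.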